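Swapping a Dimethylamino for an Oxetane-Bearing Amine

The source may hold more compounds than are shown below. What is called first, only, known or untested is meant among the compounds shown, and "the series" means these compounds.

In an ADME assay on HEp-2 cells (Homo sapiens) for cytotoxicity, read by CCK-8 assay, with a stated time of 5 days (a lower number here means that less compound is tolerated, a higher number that more compound is tolerated), compound 1 `CC(O)CNc1cc(N2CCc3ccccc3C2)nc2ccccc12` gives 89000 nM, compound 2 `NCCNc1cc(N2CCCc3ccccc3C2)nc2cc(Cl)ccc12` gives 7500 nM, and compound 3 `Cc1ccc2nc(N3CCCc4ccc(F)cc4C3)cc(NCCN(C)C)c2c1` gives 89000 nM. Compound 3 and compound 1 are level at the digits shown and together give the highest of the three numbers, while compound 2 sits clearly lower, beyond the usual scatter. Compound 4 `Cc1ccc2nc(N3CCCc4ccc(F)cc4C3)cc(NCCNC3COC3)c2c1` has not yet been measured in this assay. It differs from compound 3 in one place: (oxetan-3-yl)amino in place of dimethylamino on a saturated chain carbon, two bonds along the chain from a nitrogen on an aromatic ring. Among the measured compounds shown here, no pair of measured compounds differs in just this way, so nothing here shows how such a change moves the number. The expected step is small, a 1.1-fold lower number from compound 3 to compound 4 (0.05 log units; within the scatter), not beyond the scatter in either direction. Compound 4 is estimated at 80000 nM, with a range from 30000 nM to 160000 nM.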

Compound 4, half-maximal cytotoxic concentration: > 100000 nM
Compound 4: no number, only a limit; the forecaster's own chance of this, stated with the estimate: 15%; middle value at least 1.2-fold (0.09 log units) from the limit.
By their numbers in this assay, from the lowest: compound 2; then compounds 1 and 3 (each within the scatter of the next). At a limit, above all of these: compound 4.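

In this assay, among the compounds shown here, this is the first direct reading of swapping dimethylamino for (oxetan-3-yl)amino at this chain position, and the step is an at least 1.1-fold higher number from compound 3 to compound 4 (0.05 log units; that floor lies within the scatter), so the swap brought no sign of lower tolerance. Compound 4 gives a limit, not a number: the limit of > 100000 nM in this assay, at which 1 of the 4 values shown sits. The true size of the step therefore stays hidden, and its floor alone cannot separate compound 4 from compound 3.

From the compounds shown here alone, how far compound 4 lies past its limit remains open. So does whether a morpholine ring or a longer chain at this position would read the same way.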